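Ester chain extension in the A549 cytotoxicity series

The source may report more compounds than this note shows. Statements on the series, on what has been measured and on what is new or still open speak of the compounds shown alone.

Measured so far in a functional assay on A549 cells (Homo sapiens) for cytotoxicity, read by MTT assay, with a stated time of 24 h, tested at 20 uM; a higher number here means a weaker effect of the compound at the concentration tested, a lower number a stronger effect:
Compound 1 `CCOC(=O)CCC(=O)N1CCN(CCCOc2cc3c(Nc4ccc(F)c(Cl)c4)ncnc3cc2OC)CC1` gives 70%.
Compound 2 `CCCCCOC(=O)CCC(=O)N1CCN(CCCOc2cc3c(Nc4ccc(F)c(Cl)c4)ncnc3cc2OC)CC1` gives 81.2%.
Compound 3 `CCCCCCCCOC(=O)CCC(=O)N1CCN(CCCOc2cc3c(Nc4ccc(F)c(Cl)c4)ncnc3cc2OC)CC1` gives 80%.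

Compound 3 stands second highest of the three numbers; its nearest neighbour is compound 2 and its furthest is compound 1, both within the scatter. Compound 4 `CCCCCCCCCCCCCOC(=O)CCC(=O)N1CCN(CCCOc2cc3c(Nc4ccc(F)c(Cl)c4)ncnc3cc2OC)CC1` differs from compound 3 by pentyl in place of hydrogen on a saturated chain carbon, eight bonds along the chain from an oxygen next to a carbonyl group. The lengthening steps bear on this: a number 11.2 percentage points higher from compound 1 to compound 2 (beyond the scatter), a number 10 percentage points higher from compound 1 to compound 3 (within the scatter) and a number 1.2 percentage points lower from compound 2 to compound 3 (within the scatter). Beyond the first lengthening, no further change beyond the scatter has appeared, so for compound 4 no step beyond the scatter is expected in this assay, no change at the digits printed from compound 3 to compound 4 (within the scatter). Compound 4 is estimated at 80%, in the range 68% to 92%.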

Compound 4, a percentage reported as activity, at one concentration (the size of the read-out at that concentration, not a potency): 93.8%
Compound 4: the middle estimate sits 13.8 percentage points below what was measured, and the stated range ends below it.
By their numbers in this assay, from the lowest: compounds 1, 3 and 2 (each within the scatter of the next, the first and the last beyond it); then compound 4.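

In this assay the chain still responds to lengthening after the flat stretch between compound 2 and compound 3: pentyl in place of hydrogen on a saturated chain carbon, eight bonds along the chain from an oxygen next to a carbonyl group, gives a number 13.8 percentage points higher from compound 3 to compound 4 (beyond the scatter). Compound 4 also stands clear of the shorter chains, with a number 12.6 percentage points higher from compound 2 to compound 4 (beyond the scatter) and a number 23.8 percentage points higher from compound 1 to compound 4 (beyond the scatter), so it shows the weakest effect at the concentration tested, although compound 2 and compound 3 go against any steady rise. No measurement at hand accounts for this rise.

From the compounds shown here alone, whether a longer chain moves the number further remains open. So does the effect of a carboxylic acid at the chain end.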